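The source may report more compounds than this note shows. Statements on the series, on what has been measured and on what is new or still open speak of the compounds shown alone.

Among the measured compounds shown here, compound 3, `CCOC(=O)C1=C(C)NC(C)=C(C(=O)OCC)C1c1cnc(SC)n1Nc1ccccc1`, stands with the lowest of the three numbers known in an assay on isolated protein (strain albino) for antagonist activity at Voltage-dependent L-type calcium channel subunit alpha-1C (Cavia porcellus) (a higher number here means a weaker inhibitor, a lower number a stronger inhibitor), where compound 3 gives 1.69 nM. The two other measured compounds carry larger ester groups on the shared core. Compound 1, `CSc1ncc(C2C(C(=O)OC3CCCCC3)=C(C)NC(C)=C2C(=O)OC2CCCCC2)n1Nc1ccccc1`, gives 465 nM in this assay, and compound 2, `CSc1ncc(C2C(C(=O)OCC3CCCCC3)=C(C)NC(C)=C2C(=O)OCC2CCCCC2)n1Nc1ccccc1`, gives 621 nM. Both of these numbers lie far above that of compound 3, well beyond the usual scatter, while the two of them sit close to one another.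

Compound 4, `CCOC(=O)C1=C(C)NC(C)=C(C(=O)OCCCc2ccccc2)C1c1cnc(SC)n1Nc1ccccc1`, keeps one ethyl ester of compound 3 and changes the other: benzyl in place of hydrogen on a saturated chain carbon, two bonds along the chain from an oxygen next to a carbonyl group. The ester that changes thus grows from ethoxy to 3-phenylpropoxy, and only on one side of the core.

For the measured compounds named here, no step between two measured compounds matches this change. The comparison of compound 3 with compound 1 and compound 2 shows that enlarging both esters is accompanied by a large loss in this assay, though those two compounds differ from compound 3 in both esters at once and in a different kind of group. For compound 4 a moderate rise in the number is therefore expected, with the step of a 3.6-fold higher number from compound 3 to compound 4 (0.55 log units; beyond the scatter) estimated to stay far short of the gaps seen to compound 1 and compound 2. Compound 4 is expected to give about 6 nM in this assay, within a range from 1.2 nM to 40 nM.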

Compound 4, half-maximal inhibitory concentration: 2.54 nM
Compound 4: middle estimate off by 2.4-fold (0.37 log units), on the high side, and the stated range covers the measured number.
By their numbers in this assay, from the lowest: compounds 3 and 4 (each within the scatter of the next); then compounds 1 and 2 (each within the scatter of the next).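

In this assay the change reads as a 1.5-fold higher number from compound 3 to compound 4 (0.18 log units; within the scatter) and so stays within the usual scatter. Among the compounds shown here, this is the first step in the set that alters a single place: with one ethyl ester kept, ethoxy can give way to 3-phenylpropoxy on one side of the shared core, and the added benzyl, with its six-membered aromatic ring, leaves the number indistinguishable from that of compound 3, something compound 1 and compound 2 could not show, as each differs from compound 3 in both esters at once. No measurement is at hand that would explain this result.

The compounds shown leave open whether the same chain would be accepted on both sides of the core at once, and whether the outcome depends on the length of the link, as a benzyl or phenethyl ester would test. They also leave open whether the terminal phenyl could be replaced by a dimethylamino group or a carboxylic acid at the end of the chain without a move beyond the scatter.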